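The source may hold more compounds than are shown below. What is called first, only, known or untested is meant among the compounds shown, and "the series" means these compounds.

Measured in a functional assay on MKN-45 cells (Homo sapiens) for inhibition, with a stated time of 72 h; on this read-out higher numbers stand for weaker inhibition and lower numbers for stronger inhibition:
- compound 1 `COc1ccc(S(=O)(=O)N2CCc3cccc(-c4ccc(N(C)C)cc4)c32)cc1` gives 237 nM
- compound 2 `COc1ccc(S(=O)(=O)N2CCc3cccc(-c4cc(OC)c(OC)c(OC)c4)c32)cc1` gives 1080 nM
- compound 3 `COc1ccc(S(=O)(=O)N2CCc3cccc(-c4ccc(F)cc4)c32)cc1` gives 79 nM

Compound 3 has the lowest number of the three, so it is the strongest inhibitor in this small set. Compound 1 lies nearest to it, and compound 2 lies furthest away. Compound 4 `COc1ccc(S(=O)(=O)N2CCc3cccc(-c4ccccc4)c32)cc1` has not yet been measured. It differs from compound 3 in one place, with hydrogen in place of fluoro on an aromatic carbon, para to a large group (hydrogen in place of fluoro on an aromatic carbon).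

Among the compounds with values here, only one measured step changes a group at that same carbon: a 3.0-fold lower number from compound 1 to compound 3 (0.48 log units; beyond the scatter). There, fluoro replaced dimethylamino, and the number moved modestly but beyond the scatter. Compound 2 differs from compound 3 in more than one place, so it says little about this change. Within the data shown here, no measured pair shows directly what removing the fluoro does. Swapping fluoro for hydrogen is a much smaller structural change than swapping dimethylamino for fluoro, so a step smaller than the one to compound 3 is expected, possibly none beyond the scatter, with only a slight lean towards a higher number.

In this assay, the expected result is a 1.3-fold higher number from compound 3 to compound 4 (0.10 log units; within the scatter). For compound 4 the estimated value is 100 nM, with an expected range from 40 nM to 250 nM.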

Compound 4, half-maximal inhibitory concentration: 117 nM
Beside the measured number, compound 4's estimate is 1.2-fold (0.07 log units) below it; low and high end bracket the measured number.
By their numbers in this assay, from the lowest: compounds 3 and 4 (each within the scatter of the next); then compound 1; then compound 2.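

In this assay, the step with hydrogen in place of fluoro on this aromatic carbon is a 1.5-fold higher number from compound 3 to compound 4 (0.17 log units; within the scatter), so 4-fluorophenyl and phenyl cannot be told apart here, and the fluoro is not required for a number at this level. Within the data shown here, until now, the only change seen at this carbon was the exchange of dimethylamino for fluoro, which left open whether fluoro itself contributed anything or dimethylamino simply did worse. The unsubstituted phenyl now offers a plain reference point: the step with hydrogen in place of dimethylamino is a 2.0-fold lower number from compound 1 to compound 4 (0.31 log units; beyond the scatter), so, among these compounds, dimethylamino is the one group at this carbon that stands apart from hydrogen, though only modestly.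

The compounds shown leave open how a larger or differently built group at this same carbon, such as chloro, trifluoromethyl, a primary amine or a carboxylic acid, would compare with hydrogen in this cell assay. They also offer no separate measurement that could explain the size of either step, so the numbers describe these differences without accounting for them.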